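Methyl on the phenyl ring of compound 3

The compounds below may be only part of what the source reports. "The series", "measured", "known", "first", "only" and "open" are said of these compounds alone.

In a functional assay on MCF7 cells (Homo sapiens) for inhibition, read by CCK-8 assay, with a stated time of 48 h (on this read-out higher numbers stand for weaker inhibition and lower numbers for stronger inhibition), compound 3 `COc1cc(-c2ccnc3cc(-c4ccccc4)nn23)cc(OC)c1OC` gives 254 nM, the higher of the two actual numbers in the series. Compound 2 `COc1cc(-c2ccnc3cc(-c4cn(CO)c5ccccc45)nn23)cc(OC)c1OC` gives 19 nM, lower than compound 3 by more than the scatter. Compound 1 `COc1cc(-c2cc3nccc(-c4cc(OC)c(OC)c(OC)c4)n3n2)cc(OC)c1OC` reads > 10000 nM, which is a limit and not a number.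

Compound 4 `COc1cc(-c2ccnc3cc(-c4cccc(C)c4)nn23)cc(OC)c1OC` follows from compound 3 by one change: methyl in place of hydrogen on an aromatic carbon, meta to a large group. Going by the values given here, no measured pair shows this change, so the expectation starts from compound 3 at 254 nM. The step expected in this assay is a 1.2-fold higher number from compound 3 to compound 4 (0.07 log units; within the scatter), which is none beyond the scatter. For compound 4 the estimated value is 300 nM, with an expected range of 90 nM to 1000 nM.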

Compound 4, half-maximal inhibitory concentration: 1080 nM
The estimate for compound 4 lay 3.6-fold (0.56 log units) below the measured number; measured number outside the range, above it.
By their numbers in this assay, from the lowest: compound 2; then compound 3; then compound 4. At a limit, above all of these: compound 1.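

Going by these compounds alone, compound 3 and compound 4 form the only pair that differs in one place, so the phenyl ring can now be read directly. In this assay, methyl in place of hydrogen on an aromatic carbon, meta to a large group, gives a 4.3-fold higher number from compound 3 to compound 4 (0.63 log units; beyond the scatter), so one added carbon at this position weakens inhibition. Nothing measured here bears on why the number rises.

From the compounds shown here alone, whether methyl elsewhere on the phenyl ring gives a similar step remains open. So does the effect of fluorine, an amine or a hydroxyl at this position.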